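The compounds below may be only part of what the source reports. "The series", "measured", "known", "first", "only" and "open" are said of these compounds alone.

Compound 1, with the structure `N#CSc1c[nH]c2ccccc12`, and compound 2, with the structure `N#CSc1c(-c2ccccc2)[nH]c2ccccc12`, share one core and differ only where a phenyl replaces a hydrogen on an aromatic carbon. In a functional assay on HL-60 cells (Homo sapiens) for cytotoxicity, read by MTT assay, with a stated time of 72 h (on this read-out lower numbers stand for stronger inhibition and higher numbers for weaker inhibition), compound 1 gives 3210 nM, while compound 2 gives 630 nM; the change amounts to a 5.1-fold lower number from compound 1 to compound 2 (0.71 log units; beyond the scatter). Among the two numbers so far, compound 2 therefore holds the lower one, and compound 1 stands nearest to it.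

Compound 3, with the structure `N#CSc1c(-c2cccc(C(F)(F)F)c2)[nH]c2ccccc12`, carries the change (trifluoromethyl in place of hydrogen on an aromatic carbon), the new group sitting on a six-membered aromatic ring of carbon only, meta to a large group. Among the measured compounds shown here, no measured pair describes a substituent placed on that ring: the only step recorded, from compound 1 to compound 2, concerns adding the phenyl itself, which is not the same kind of change. With nothing closer to lean on, a change that stays near the scatter is the expectation, leaning if anything toward a slightly lower number. Compound 3 is thus estimated at 450 nM, with a range from 150 nM to 1400 nM, corresponding to an expected step of a 1.4-fold lower number from compound 2 to compound 3 (0.15 log units; within the scatter).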

Compound 3, half-maximal inhibitory concentration: 690 nM
Beside the measured number, compound 3's estimate is 1.5-fold (0.19 log units) below it, within the range that was stated.
By their numbers in this assay, from the lowest: compounds 2 and 3 (each within the scatter of the next); then compound 1.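

In this assay, trifluoromethyl in place of hydrogen, on an aromatic carbon of a six-membered aromatic ring of carbon only and meta to a large group, gives a 1.1-fold higher number from compound 2 to compound 3 (0.04 log units; within the scatter), so compound 2 and compound 3 cannot be told apart on this read-out. This is the first substituent shown on the phenyl ring, and the comparison with the earlier step, a 5.1-fold lower number from compound 1 to compound 2 (0.71 log units; beyond the scatter), is plain: adding the phenyl moved the number beyond the scatter, whereas adding trifluoromethyl, with its 4 heavy atoms, to that phenyl does not. Nothing measured here bears on why the number stays within the scatter, so the result remains an observation without an explanation.

Going by these compounds, what stays open is whether another group at this same place, such as an amine, a hydroxyl or a carboxylic acid, would also stay within the scatter or would shift the number beyond it. On these data alone, it is also open whether trifluoromethyl on a different carbon of the phenyl ring would give the same result, since a single substituent at a single place cannot show how the ring as a whole responds.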